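The compounds below may be only part of what the source reports. "The series", "measured", "known", "first", "only" and "open" are said of these compounds alone.

Three close relatives have been measured in a functional assay on A549 cells (Homo sapiens) for antiproliferative activity, read by MTT assay, with a stated time of 48 h; on this read-out higher numbers stand for weaker inhibition and lower numbers for stronger inhibition. Compound 1 `COc1ccc2c(/C=C/C(=O)c3cc(OC)c(OC)c(SC)c3)c[nH]c2c1` gives 115 nM, compound 2 `COc1ccc2c(/C=C/C(=O)c3cc(N)c(OC)c(OC)c3)c[nH]c2c1` gives 193 nM and compound 3 `COc1ccc2c(/C=C/C(=O)c3cc(N)c(OC)c(OC)c3)cn(C)c2c1` gives 106 nM. Compound 1 therefore sits within the scatter of both relatives, and the three numbers cannot be ranked.

Compound 4 `COc1cc(C(=O)/C=C/c2c[nH]c3ccccc23)cc(SC)c1OC` has not yet been measured. Its difference from compound 1 is hydrogen in place of methoxy on an aromatic carbon, on the ring system that is part of a fused or bridged system of two rings.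

Two measured steps are available, a 1.7-fold higher number from compound 1 to compound 2 (0.22 log units; within the scatter) and a 1.8-fold lower number from compound 2 to compound 3 (0.26 log units; within the scatter). Neither swaps this methoxy, so they bear on the question only indirectly: they show that two other changes left the number within the scatter. For the measured compounds named here, all three measured compounds keep the methoxy, so the data contain no direct example of losing it. The direction is therefore a cautious judgement, leaning towards weaker inhibition in this assay, with a wide range to reflect the missing evidence.

The estimate amounts to an expected 3.0-fold higher number from compound 1 to compound 4 (0.48 log units; beyond the scatter). For compound 4 the expected value is 350 nM, with an estimated range from 100 nM to 1500 nM.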

Compound 4, half-maximal inhibitory concentration: 152 nM
For compound 4 the middle estimate is 2.3-fold (0.36 log units) above the measured one; the measured number falls inside the stated range.
By their numbers in this assay, from the lowest: compounds 3, 1, 4 and 2 (each within the scatter of the next).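

Compound 4 gives the first direct view of this position: in this assay hydrogen takes the place of the methoxy on the six-membered aromatic ring of carbon only, part of a fused or bridged system of two rings, and the step is small (a 1.3-fold higher number from compound 1 to compound 4 (0.12 log units; within the scatter)). For this pair, then, the methoxy, with its 2 heavy atoms and 1 hydrogen-bond acceptor, can go without the number moving beyond the usual scatter, so this swap joins the two earlier ones that also stayed within it. Nothing at hand explains this result, so the pair records what happened and offers no cause.

Going by these compounds, this is one swap on one parent, so it remains open whether a hydroxyl group, a chlorine atom or a longer chain such as ethoxy at this place would also stay within the scatter. Also open, on these data alone, is whether hydrogen in place of this methoxy would read the same on compound 2 or compound 3, which carry the amino group, and whether the result would hold outside this assay.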